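The source may report more compounds than this note shows. Statements on the series, on what has been measured and on what is new or still open speak of the compounds shown alone.

Of the compounds shown here, three have so far been tested in a functional assay on KB 3-1 cells (Homo sapiens) for cytotoxicity, read by MTT assay, with a stated time of 68 h; a lower number here means a stronger inhibitor, a higher number a weaker inhibitor.

Compound 1, `O=C(Nc1cccc(-c2cccc(F)c2)c1)C(Cl)Cl`, gives > 50000 nM, which is a limit of the assay.
Compound 2, `COC(=O)c1ccc(-c2cccc(NC(=O)C(Cl)Cl)c2)cc1`, gives > 50000 nM, again a limit of the assay.
Compound 3, `O=C(Nc1cccc(-c2cccc(Cl)c2)c1)C(Cl)Cl`, gives > 50000 nM, once more a limit of the assay.

Among the compounds with values here, the only step between compounds that differ in one place, a step that the two limits leave unreadable from compound 1 to compound 3, cannot be read: both of its values are limits. Compound 2 therefore stands at the limit of this assay, and it shares that position with the two other values shown, as the limit of > 50000 nM in this assay, at which 3 of the 3 values shown sit, makes plain. The compound not yet measured is compound 4, `COc1ccc(-c2cccc(NC(=O)C(Cl)Cl)c2)cc1`, which differs from compound 2 by methoxy in place of methoxycarbonyl on an aromatic carbon. Within the data shown here, no measured step bears on this change, and none of the measured values lies inside the range of this assay, so no size or direction of step in this assay can be drawn from the data. Compound 4 is expected to give about 60000 nM, in the range 20000 nM to 200000 nM. The expected step from compound 2 is accordingly estimated as a step that the limit leaves unreadable from compound 2 to compound 4, with a strong chance that compound 4 is again reported only as a limit.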

Compound 4, half-maximal inhibitory concentration: > 50000 nM
Compound 4: a limit, no number; the forecaster's own chance of this, stated with the estimate: 85%; the middle value does not contradict the limit.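

Compound 2 and compound 4 are both reported only as limits, so no new step can be read between them: the limit of > 50000 nM in this assay, at which 4 of the 4 values shown sit. The compounds shown leave open how large the effect of methoxy in place of methoxycarbonyl is, and whether any of them reaches a readable value in this assay at all.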